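Replacing methoxy with dimethylsulfamoyl in compound 3

The source may report more compounds than this note shows. Statements on the series, on what has been measured and on what is new or still open speak of the compounds shown alone.

In a functional assay on Huh-5-2 cells (Homo sapiens), read by MTT assay (a higher number here means that more compound is tolerated, a lower number that less compound is tolerated), compound 1 `O=C(O)c1ccc(-c2ccc(Cl)cc2COc2ccc(-c3nc4cc(C(=O)O)ccc4n3C3CCCCC3)cc2)cc1` gives > 50000 nM, which is a limit of the assay and not a number. Compound 2 `O=C(O)c1ccc2c(c1)nc(-c1ccc(OCc3ccccc3-c3ccc(Cl)cc3)cc1)n2C1CCCCC1` gives 25000 nM. Compound 3 `COc1ccc(-c2ccc(Cl)cc2)c(COc2ccc(-c3nc4cc(C(=O)O)ccc4n3C3CCCCC3)cc2)c1` gives 24000 nM. Within the data shown here, that places it level with compound 2 within the scatter, and these two are the only true numbers so far.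

Compound 4 `CN(C)S(=O)(=O)c1ccc(-c2ccc(Cl)cc2)c(COc2ccc(-c3nc4cc(C(=O)O)ccc4n3C3CCCCC3)cc2)c1` has not been measured. It differs from compound 3 at one place: dimethylsulfamoyl in place of methoxy on an aromatic carbon. Dimethylsulfamoyl takes the place of methoxy on an aromatic carbon, para to a 4-chlorophenyl group.

Among the measured compounds shown here, only one measured step bears on this carbon: methoxy in place of hydrogen gave a 1.0-fold lower number from compound 2 to compound 3 (0.02 log units; within the scatter). For the measured compounds named here, that step was small, but no measured compound carries dimethylsulfamoyl, so it is only a weak guide. Going by a 1.0-fold lower number from compound 2 to compound 3 (0.02 log units; within the scatter), no shift beyond the scatter is expected in either direction. The expected step is a 1.1-fold higher number from compound 3 to compound 4 (0.05 log units; within the scatter). For compound 4 the estimated value is 27000 nM. The expected range runs from 12000 nM to 50000 nM.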

Compound 4, half-maximal cytotoxic concentration: 26000 nM
The estimate for compound 4 lay 1.0-fold (0.02 log units) above the measured number; the measured number falls inside the stated range.
By their numbers in this assay, from the lowest: compounds 3, 2 and 4 (each within the scatter of the next). At a limit, above all of these: compound 1.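

In this assay, the change gives a 1.1-fold higher number from compound 3 to compound 4 (0.03 log units; within the scatter), and the comparison with hydrogen on the same carbon gives a 1.0-fold higher number from compound 2 to compound 4 (0.02 log units; within the scatter). This aromatic carbon, para to a 4-chlorophenyl group, has now carried hydrogen, methoxy and dimethylsulfamoyl, and even the last of these, with 6 heavy atoms against 2 for methoxy, moves the number no further than the scatter. Compound 4 still gives a true number, and only compound 1 stands at a limit of the assay: the limit of > 50000 nM in this assay, at which 1 of the 4 values shown sits.

On these data alone, whether an amine, a carboxylic acid or a longer chain on this carbon would also leave the number in place remains open. The compounds shown also leave open whether the other carbons of this ring tolerate such changes in the same way.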